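Swapping tert-butyl for neopentyl in compound 3

A few compounds are considered here, and "the series" means these few. Any claim that something is new, unique, unknown or untested is made for them only; others in the source may bear on it.

In a functional assay for inhibition, with Rattus norvegicus as the target (a lower number here means a stronger inhibitor, a higher number a weaker inhibitor), compound 1 `COc1ncccc1/N=c1\c(O)c(O)\c1=N/C(C)(C)C` gives 2560 nM and compound 2 `CC(=O)c1ccc(/N=c2\c(O)c(O)\c2=N/C(C)C(C)(C)C)cc1` gives 21200 nM while compound 3 `CC(C)(C)/N=c1\c(O)c(O)\c1=N/c1ccc(C#N)cc1` gives 560 nM as the lowest number of the three, clearly beyond the scatter from both others. Compound 4 `CC(C)(C)C/N=c1\c(O)c(O)\c1=N/c1ccc(C#N)cc1` differs from compound 3 by a single change neopentyl in place of tert-butyl on a double-bonded nitrogen with neopentyl in place of tert-butyl on a double-bonded nitrogen. Going by the values given here, no measured pair differs in one place alone, so the data show nothing direct about this swap. The estimated step of a 1.8-fold higher number from compound 3 to compound 4 (0.25 log units; within the scatter) in this assay is a modest rise in the number, meaning a somewhat weaker inhibitor, and it may not go far beyond the scatter. For compound 4 the expected value is 1000 nM with a likely range from 250 nM to 4000 nM as an estimate.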

Compound 4, half-maximal inhibitory concentration: > 30000 nM
Compound 4: only a limit was reported; the forecaster's own chance of this, stated with the estimate: 5%; middle value at least 30-fold (1.47 log units) from the limit.
By their numbers in this assay, from the lowest: compound 3; then compound 1; then compound 2. At a limit, above all of these: compound 4.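

Neopentyl in place of tert-butyl on a double-bonded nitrogen gives an at least 53-fold higher number from compound 3 to compound 4 (1.72 log units; beyond the scatter) in this assay, making compound 4 a far weaker inhibitor. Going by these compounds alone, the earlier compounds differ in more than one place, so this is the first direct sign that this group alone can decide the result, even when the swap adds a single carbon. Compound 4 gives only a limit of the assay: the limit of > 30000 nM in this assay, at which 1 of the 4 values shown sits.

From the compounds shown here alone, whether other groups at this nitrogen lose as much stays open: isopropyl, cyclopropyl or a longer chain could show how narrow the demand is. Why neopentyl fares so badly also stays unanswered.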